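Stretching the aryl ether chain from fluorinated to prenyl

This account rests on a few compounds, and the source may have more. Where it says the series, first, only, none or still open, it means among the compounds named here.

Measured compounds:
- compound 1 `O=C(NNC(=O)C1CC1c1ccc(OC(F)(F)F)cc1)c1ccncc1`: 37000 nM
- compound 2 `COc1ccc(C2CC2C(=O)NNc2nncc3ccccc23)cc1`: 83000 nM
- compound 3 `O=C(NNC(=O)C1CC1c1ccc(OCC(F)(F)F)cc1)c1ccncc1`: 19000 nM

Three compounds share a cyclopropane carrying an aryl ether on one side and a hydrazide on the other. In a functional assay on U-373MG ATCC cells (Homo sapiens) for inhibition, read by MTT assay, with a stated time of 72 h (a lower number here means a stronger inhibitor, a higher number a weaker inhibitor), compound 1 gives 37000 nM, compound 2 gives 83000 nM and compound 3 gives 19000 nM. Compound 3 has the lowest number of the three; the gap to compound 1 is within the scatter, while the gap to compound 2 is beyond it, so compound 3 and compound 1 cannot be told apart, and only compound 2 stands clearly higher.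

Compound 4 `CC(C)=CCOc1ccc(C2CC2C(=O)NNC(=O)c2ccncc2)cc1` differs from compound 3 at the end of the ether chain: 2-methylprop-1-en-1-yl in place of trifluoromethyl on a saturated chain carbon bound to an oxygen on an aromatic ring. Among the measured compounds shown here, the only measured step that touches this part of the molecule is a 1.9-fold lower number from compound 1 to compound 3 (0.29 log units; within the scatter), and that step is within the scatter. Nothing measured covers a swap of a fluorinated group for an alkenyl group, so the expectation rests on that single small step alone. The step of a 1.2-fold higher number from compound 3 to compound 4 (0.06 log units; within the scatter) is therefore expected to stay within the scatter. Compound 4 is estimated at 22000 nM, with a range from 7000 nM to 70000 nM.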

Compound 4, half-maximal inhibitory concentration: > 100000 nM
Compound 4 gave a limit, no number; the forecaster's own chance of this, stated with the estimate: 10%; middle value at least 4.5-fold (0.65 log units) away from the limit.
By their numbers in this assay, from the lowest: compounds 3 and 1 (each within the scatter of the next); then compound 2. At a limit, above all of these: compound 4.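

Compound 4 stands at a limit of the assay, not at a number, in this assay: the limit of > 100000 nM in this assay, at which 1 of the 4 values shown sits. Even so, the comparison with the two fluorinated ethers can be read, with an at least 5.2-fold higher number from compound 3 to compound 4 (0.72 log units; beyond the scatter) and an at least 2.7-fold higher number from compound 1 to compound 4 (0.43 log units; beyond the scatter). This shows that the end of the ether chain is not indifferent to change: the swap between the two fluorinated groups, a 1.9-fold lower number from compound 1 to compound 3 (0.29 log units; within the scatter), left the number within the scatter, whereas the 3-methylbut-2-en-1-yl chain on the same oxygen clearly moves it towards weaker inhibition.

As far as these compounds go, how far the true value of compound 4 lies past its limit remains unknown, so the full size of this loss cannot be stated. The compounds shown also cannot tell whether the change follows from the double bond, the branched chain end or the loss of fluorine, and a saturated 3-methylbutyl chain, or a chain ending in an amine or a carboxylic acid, would test this position in ways these four compounds cannot.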